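A few compounds are considered here, and "the series" means these few. Any claim that something is new, unique, unknown or untested is made for them only; others in the source may bear on it.

Measured compounds:
compound 1 `O=C(N/N=C/c1ccccc1)c1cnccn1` — 75%
compound 2 `CCOc1cccc(/C=N/NC(=O)c2cnccn2)c1` — 71%

In an ADME assay on J774 cells (Mus musculus) for cytotoxicity, read by MTT assay, with a stated time of 48 h, tested at 100 ug/mL (on this read-out higher numbers stand for a weaker effect at the one concentration tested and lower numbers for a stronger effect), compound 1 gives 75%, and compound 2, which carries ethoxy in place of hydrogen on an aromatic carbon, gives 71%. The single measured step, a number 4 percentage points lower from compound 1 to compound 2 (within the scatter), lies within the scatter, so on the numbers shown compound 2 and compound 1 stand together; compound 2 has no neighbour other than compound 1, and the gap between them is within the scatter.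

Compound 3 `O=C(N/N=C/c1cccc(O)c1)c1cnccn1` has not yet been measured in this assay. Its difference from compound 2: hydrogen in place of ethyl on an oxygen on an aromatic ring The ethyl leaves the oxygen and a hydroxy remains on the ring. Within the data shown here, the only step that bears on this change is the one in which the ethoxy entered, a number 4 percentage points lower from compound 1 to compound 2 (within the scatter), and that step was within the scatter. With the oxygen kept and only the ethyl removed, no step beyond the scatter is expected. The step to compound 3 is therefore estimated as a number 2 percentage points higher from compound 2 to compound 3 (within the scatter), within the scatter. Compound 3 is expected to give about 73% in this assay, with a range from 60% to 86%.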

Compound 3, a percentage reported as activity, at one concentration (the size of the read-out at that concentration, not a potency): 100%
Beside the measured number, compound 3's estimate is 27 percentage points below it, outside the stated range (above it).
By their numbers in this assay, from the lowest: compounds 2 and 1 (each within the scatter of the next); then compound 3.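

In this assay, the ring position that looked silent when ethoxy and hydrogen stood within the scatter of each other is not silent for every group: taking the ethyl off the oxygen gives a number 29 percentage points higher from compound 2 to compound 3 (beyond the scatter) and setting hydroxy against hydrogen gives a number 25 percentage points higher from compound 1 to compound 3 (beyond the scatter) on the same read-out. Both steps point the same way, towards a weaker effect at the one concentration tested, so the hydroxy compound separates from both earlier compounds, and keeping the oxygen on the ring does not by itself keep the read-out where it was. No measurement shown here accounts for the difference between hydroxy and ethoxy.

The compounds shown leave open whether this separation belongs to hydroxy alone or would also appear with an amine or a carboxylic acid at the same place, and whether methoxy or a longer chain on the oxygen would read with ethoxy or with hydroxy. With a single concentration and one hydroxy compound, they also leave open how far this step carries to other positions on the ring or to other concentrations.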